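The compounds below may be only part of what the source reports. "The series", "measured", "known", "first", "only" and "open" are said of these compounds alone.

Measured so far in an assay on isolated protein for inhibition of matrix metalloproteinase-9 (Homo sapiens); on this read-out lower numbers stand for stronger inhibition and higher numbers for weaker inhibition:
- compound 1 `O=C(OCc1ccccc1)c1cccc(=O)[nH]1`: 69000 nM
- compound 2 `O=C(OCc1ccc(C(F)(F)F)cc1)c1cccc(=O)[nH]1`: 101000 nM

Of the two numbers in this assay, compound 2 has the higher one; its nearest neighbour is compound 1, and the step of a 1.5-fold higher number from compound 1 to compound 2 (0.17 log units; within the scatter) does not exceed the scatter, so the two compounds cannot be set in order on these data.

Compound 3 `Cc1ccc(COC(=O)c2cccc(=O)[nH]2)cc1` is the next member of the series and differs from compound 2 by one change: methyl in place of trifluoromethyl on an aromatic carbon. Among the measured compounds shown here, only one measured step touches this position on the ring, namely a 1.5-fold higher number from compound 1 to compound 2 (0.17 log units; within the scatter), and that step stayed within the scatter. Nothing in the measured pair therefore points to a shift of any size, in either direction, when the group at this position is exchanged again. The step of a 1.2-fold lower number from compound 2 to compound 3 (0.07 log units; within the scatter) is accordingly expected to stay within the scatter. For compound 3 the estimate in this assay is 85000 nM, with a range from 35000 nM to 200000 nM; a reported limit instead of a number is possible given how weak both measured compounds are.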

Compound 3, half-maximal inhibitory concentration: 68000 nM
The estimate for compound 3 lay 1.3-fold (0.10 log units) above the measured number, within the range that was stated.
By their numbers in this assay, from the lowest: compounds 3, 1 and 2 (each within the scatter of the next).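

In this assay the exchange of trifluoromethyl for methyl on the aromatic carbon para to a large group gives a 1.5-fold lower number from compound 2 to compound 3 (0.17 log units; within the scatter) and methyl in place of hydrogen on that same carbon gives a 1.0-fold lower number from compound 1 to compound 3 (0.01 log units; within the scatter) so that hydrogen, methyl and trifluoromethyl can now all be compared at this position. Before compound 3 there was a single step here; now all three steps among these groups stay within the scatter, even though the trifluoromethyl group that leaves counts 4 heavy atoms and the methyl group that enters counts 1. No independent measurement is available that bears on why these numbers lie so close together.

The three compounds leave open whether an amine, a carboxylic acid or a longer chain such as n-butyl on this aromatic carbon would move the number beyond the scatter, since only hydrogen, methyl and trifluoromethyl are shown there. They also leave open whether a change elsewhere on the shared core, such as methyl in place of the amide hydrogen, would produce a step larger than any seen at this position.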